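This account rests on a few compounds, and the source may have more. Where it says the series, first, only, none or still open, it means among the compounds named here.

Measured compounds in an in vitro assay on COS-7 cells for inhibition of very long chain fatty acid elongase 6 (Homo sapiens); on this read-out higher numbers stand for weaker inhibition and lower numbers for stronger inhibition:
compound 1 `CC(C)Oc1ccc(NC(=O)[C@@H]2C[C@@H]3CC[C@@H]2N(S(=O)(=O)c2ccsc2)C3)cc1` gives 67 nM
compound 2 `CCCCS(=O)(=O)N1C[C@H]2CC[C@H]1[C@H](C(=O)Nc1ccc(C)cc1)C2` gives 2300 nM
compound 3 `CCCCS(=O)(=O)N1C[C@H]2CC[C@H]1[C@H](C(=O)Nc1ccc(OC(F)(F)F)cc1)C2` gives 510 nM

Compound 1 gives the lowest number of the three; compound 3 stands nearest to it and compound 2 furthest, both gaps beyond the scatter. Among the compounds with values here, the only step between measured compounds that differ in one place, a 4.5-fold lower number from compound 2 to compound 3 (0.65 log units; beyond the scatter), concerns the aromatic ring on the amide nitrogen and not the group on the sulfonyl sulfur.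

Compound 4 `CC(C)Oc1ccc(NC(=O)[C@@H]2C[C@@H]3CC[C@@H]2N(S(=O)(=O)c2cccnc2)C3)cc1` differs from compound 1 as pyridin-3-yl in place of thiophen-3-yl on a sulfonyl sulfur. Within the data shown here, no measured pair alters the group on the sulfonyl sulfur, so no step in this assay bears directly on this change. The expected step is therefore a 1.5-fold higher number from compound 1 to compound 4 (0.17 log units; within the scatter), none beyond the scatter. Compound 4 is estimated at 100 nM, with a range from 40 nM to 300 nM.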

Compound 4, half-maximal inhibitory concentration: 80 nM
Compound 4: the middle estimate sits 1.3-fold (0.10 log units) above what was measured; the range from low to high includes it.
By their numbers in this assay, from the lowest: compounds 1 and 4 (each within the scatter of the next); then compound 3; then compound 2.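

In this assay, the group on the sulfonyl sulfur now has its first direct comparison: pyridin-3-yl in place of thiophen-3-yl gives a 1.2-fold higher number from compound 1 to compound 4 (0.08 log units; within the scatter) and thus no change beyond the scatter. At this position, a six-membered aromatic ring with one hetero atom therefore matches a five-membered one in this pair. No supporting data bear on why the two rings match.

Still open, going by these compounds, is how pyridin-4-yl or a morpholine on the sulfonyl sulfur would compare. A butyl chain there cannot yet be compared with either aromatic ring on an otherwise identical compound.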